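Moving the chlorine on the benzylsulfanyl group

The source may report more compounds than this note shows. Statements on the series, on what has been measured and on what is new or still open speak of the compounds shown alone.

Compound 3 `Cc1cc(S(=O)(=O)/N=C(\N)n2nccc2-c2ccccc2)c(SCc2ccccc2Cl)cc1Cl` gives 19000 nM in a functional assay on HeLa cells (Homo sapiens) for cytotoxicity, read by MTT assay, with a stated time of 72 h (a higher number here means a weaker inhibitor, a lower number a stronger inhibitor), the highest of the three numbers measured. Among the compounds with values here, compound 1 `Cc1cc(S(=O)(=O)/N=C(\N)n2nccc2-c2ccccc2)c(SCc2ccccc2)cc1Cl` gives 5000 nM, and the step of a 3.8-fold higher number from compound 1 to compound 3 (0.58 log units; beyond the scatter) is the only measured change on this benzyl ring. Within the data shown here, compound 2 `Cc1cc(-c2ccccc2)n(/C(N)=N/S(=O)(=O)c2cc(C)c(Cl)cc2SCc2ccc(Cl)cc2)n1`, which carries a 4-chlorobenzyl group but also differs in the shared core, gives 3000 nM; no single-point step between compound 2 and any other compound is counted here. Compound 4 `Cc1cc(S(=O)(=O)/N=C(\N)n2nccc2-c2ccccc2)c(SCc2ccc(Cl)cc2)cc1Cl` differs from compound 3 by 4-chlorophenyl in place of 2-chlorophenyl on a saturated chain carbon bound to a sulfur. Among the measured compounds shown here, no measured step follows this exact move, but because a 3.8-fold higher number from compound 1 to compound 3 (0.58 log units; beyond the scatter) was only modest and because compound 2 gives 3000 nM, compound 4 is expected to show a 3.8-fold lower number from compound 3 to compound 4 (0.58 log units; beyond the scatter), a lower number. Compound 4 is estimated at 5000 nM, between 2000 nM and 15000 nM.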

Compound 4, half-maximal inhibitory concentration: 3000 nM
The estimate for compound 4 lay 1.7-fold (0.22 log units) above the measured number; the range from low to high includes it.
By their numbers in this assay, from the lowest: compounds 2, 4 and 1 (each within the scatter of the next); then compound 3.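

In this assay, moving the chlorine to the 4-position of the benzyl ring gives a 6.3-fold lower number from compound 3 to compound 4 (0.80 log units; beyond the scatter), so the position of the chlorine matters here, not merely its presence. The 4-chlorobenzyl group stays level with unsubstituted benzyl, at a 1.7-fold lower number from compound 1 to compound 4 (0.22 log units; within the scatter), and hydrogen in place of methyl on an aromatic carbon gives no change at the digits printed from compound 2 to compound 4 (within the scatter). Nothing available explains why the 2-chlorobenzyl group differs. The compounds shown leave open how a 4-methoxybenzyl or 4-fluorobenzyl group would read in place of 4-chlorobenzyl.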